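A few compounds are considered here, and "the series" means these few. Any claim that something is new, unique, unknown or untested is made for them only; others in the source may bear on it.

Measured compounds:
- compound 1 `N/C(=N\NC(=S)N1CCOCC1)c1ccccn1`: 44.5%
- compound 2 `Cc1ccnc(/C(N)=N/NC(=S)N2CCOCC2)c1`: 5.07%
- compound 3 `N/C(=N\NC(=S)N1CCSCC1)c1ccccn1`: 29%

In a functional assay on MCF7 cells (Homo sapiens) for cytotoxicity, read by MTT assay, with a stated time of 72 h, tested at 3 uM (a lower number here means less inhibition of growth, a higher number more inhibition of growth at the concentration tested), compound 1 gives 44.5%, the highest of the three numbers, with compound 3 nearest and compound 2 furthest. Both measured steps from compound 1 lead downward beyond the scatter: a number 39.4 percentage points lower from compound 1 to compound 2 (beyond the scatter), and a number 15.5 percentage points lower from compound 1 to compound 3 (beyond the scatter).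

Compound 4 `N/C(=N\NC(=S)N1CCOCC1)c1ccc(F)cn1` differs from compound 1 by fluoro in place of hydrogen on an aromatic carbon. Within the data shown here, the step that bears on it most closely is the one to compound 2, where a substituent also entered an aromatic carbon of the same ring and the number fell sharply, a number 39.4 percentage points lower from compound 1 to compound 2 (beyond the scatter). The step to compound 3, which changed the group on the thiocarbonyl carbon, is less closely related but also lowered the number, a number 15.5 percentage points lower from compound 1 to compound 3 (beyond the scatter). On this basis a downward step is expected for compound 4, though fluoro is a smaller group than methyl and the two entering positions are not the same, so the expected drop is estimated as smaller than that to compound 2, a number 16.5 percentage points lower from compound 1 to compound 4 (beyond the scatter). Compound 4 is therefore estimated at 28%, with a range from 8% to 50%.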

Compound 4, percent growth inhibition at one concentration: 33.9%
The estimate for compound 4 lay 5.9 percentage points below the measured number; the measured number falls inside the stated range.
By their numbers in this assay, from the lowest: compound 2; then compounds 3 and 4 (each within the scatter of the next); then compound 1.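

Fluoro in place of hydrogen on the aromatic carbon two atoms from the ring nitrogen and para to a large group gives a number 10.6 percentage points lower from compound 1 to compound 4 (beyond the scatter) in this assay and shows that a single fluorine atom at this carbon is enough to lower the number. Both ring changes shown, methyl in compound 2 and fluoro in compound 4, now lower the number from compound 1, with no compound going against this, but the fluoro step is modest where the methyl step was large. Nothing measured here accounts for the drop or for the difference in size between the two steps.

The compounds shown leave open how chloro, methoxy or an amine would behave on this same carbon. They also leave open whether fluoro on the carbon that carries methyl in compound 2 would give a step closer to the large one or the modest one.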